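Removing the Carbamate on the Piperidine Nitrogen: Compound 4

The source may report more compounds than this note shows. Statements on the series, on what has been measured and on what is new or still open speak of the compounds shown alone.

Three measured compounds share a core and differ at the group on the ring nitrogen. Compound 1 `CC(C)(C)OC(=O)N1CCC(O[C@H]2CC[C@H](Oc3ccc(S(C)(=O)=O)cn3)CC2)CC1` gives 108% in a functional assay on isolated protein for agonist activity at Glucose-dependent insulinotropic receptor (Rattus norvegicus), read by HTRF and cAMP accumulation; a lower number here means a smaller maximal response, a higher number a larger maximal response. Compound 2 `C[C@H](CF)OC(=O)N1CCC(O[C@H]2CC[C@H](Oc3cnc(S(C)(=O)=O)cn3)CC2)CC1` gives 115% in this assay, and compound 3 `CS(=O)(=O)c1cnc(O[C@H]2CC[C@H](OC3CCN(C(=O)OC4CCOC4)CC3)CC2)cn1` gives 109%. Among the measured compounds shown here, the one step between structures that differ in one place, a number 6 percentage points lower from compound 2 to compound 3 (within the scatter), stays within the scatter. Compound 3 stands second of the three numbers; its value and that of compound 1 lie within the scatter of each other, as do its value and that of compound 2, so all three show a maximal response close to the reference.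

Compound 4 `CS(=O)(=O)c1cnc(O[C@H]2CC[C@H](OC3CCN(CC4(C(F)(F)F)CCCC4)CC3)CC2)cn1` is the unmeasured member. Compared with compound 3, (a group of 10 heavy atoms (7 carbon, 3 fluorine; one five-membered non-aromatic ring of carbon only) in place of a group of 8 heavy atoms (5 carbon, 3 oxygen; one five-membered non-aromatic ring with 1 hetero atom), on an amine nitrogen in a ring). For the measured compounds named here, no measured step touches this kind of change: the only step on record, a number 6 percentage points lower from compound 2 to compound 3 (within the scatter), swapped one group on the oxygen of the carbamate for another and did not move the number beyond the scatter. As far as these compounds go, the carbonyl and its oxygens are retained in every measured compound, so their removal is unexplored here.

With nothing in the data to suggest a loss of maximal response, compound 4 is expected to stay near the others, with an estimated 104% (range 85% to 123%), a step of a number 5 percentage points lower from compound 3 to compound 4 (within the scatter) that is expected to lie within the scatter.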

Compound 4, largest response reached (Emax), in percent of the reference or control that the assay uses: 88%
Compound 4: middle estimate off by 16 percentage points, on the high side; the range from low to high includes it.
By their numbers in this assay, from the lowest: compound 4; then compounds 1, 3 and 2 (each within the scatter of the next).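

In this assay, among the compounds shown here, the group on the amine nitrogen in a ring proves able to change the maximal response: the record now shows a number 21 percentage points lower from compound 3 to compound 4 (beyond the scatter) and also a number 27 percentage points lower from compound 2 to compound 4 (beyond the scatter) where the only earlier step, a number 6 percentage points lower from compound 2 to compound 3 (within the scatter), had exchanged one group on the carbamate oxygen for another. Replacing the carbonyl-bearing groups on this nitrogen with a carbon and fluorine group that has a five-membered non-aromatic ring of carbon only therefore matters more than any variation among the carbamates compared so far, although compound 4 still reaches 88% in this assay and so retains a clear response. No measurement at hand speaks to the reason for the drop.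

The change removes the carbonyl and brings in the new ring and the fluorines at once, so the compounds shown cannot assign the drop to any one of these. As far as these compounds go, whether a simple acetyl group on this nitrogen would restore the response, or a cyclopentylmethyl group without the trifluoromethyl would bring it closer to that of the carbamates, remains open.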